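Removing a methyl from a core that shows no inhibition

A few compounds are considered here, and "the series" means these few. Any claim that something is new, unique, unknown or untested is made for them only; others in the source may bear on it.

Compound 2 `CCOC(=O)CSc1nncc2c(C)nc(C)n12` and compound 3 `Cc1ncn2c(S)nncc12` share a fused core; the difference between the two cores is not broken down here. Compound 1 `Sc1nncc2cncn12` arises from compound 3 by hydrogen in place of methyl on an aromatic carbon. In a functional assay for inhibition, with Homo sapiens as the target (a lower number here means a stronger inhibitor, a higher number a weaker inhibitor), compound 3 gives only a limit, > 48000 nM. In this assay compound 1 also gives only a limit, > 48000 nM. The step that the two limits leave unreadable from compound 3 to compound 1 therefore cannot be read. Compound 2 too gives only a limit in this assay, > 48000 nM, so that (the limit of > 48000 nM in this assay, at which 3 of the 3 values shown sit). Compound 4 `CCOC(=O)CSc1nncc2c(C)ncn12` arises from compound 2 by hydrogen in place of methyl on an aromatic carbon, the same kind of change as from compound 3 to compound 1, though there the place was next to the ring nitrogen and here it is between two ring nitrogen atoms. Because (the limit of > 48000 nM in this assay, at which 3 of the 3 values shown sit), the step is expected to be close to a step that the limit leaves unreadable from compound 2 to compound 4. Compound 4 is thus estimated at roughly 60000 nM, most likely reported again only as a limit.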

Compound 4, half-maximal inhibitory concentration: > 48000 nM
Compound 4: no number, only a limit; the forecaster's own chance of this, stated with the estimate: 90%; the middle value lies beyond the limit too.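

Compound 2 and compound 4 both give only a limit, so no step between them can be read: the limit of > 48000 nM in this assay, at which 4 of the 4 values shown sit.

The compounds shown leave open whether hydrogen in place of methyl changes inhibition at all.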